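The source may report more compounds than this note shows. Statements on the series, on what has been measured and on what is new or still open speak of the compounds shown alone.

Working notes on a physicochemical assay for solubility, measured as kinetic solubility (a lower number here means a less soluble compound, a higher number a more soluble compound), covering three measured compounds and one still to be measured. Compound 1 `CC(=O)Nc1c(F)cc(C(=O)N[C@H]2CC[C@H](O)CC2)cc1O[C@@H](C)c1ccccc1` reads >= 159 ug/mL, which is a limit of the assay and not a number. Compound 2 `CNC(=O)c1cc(C(=O)N[C@H]2CC[C@H](O)CC2)c([C@@H](C)c2cccc(F)c2)o1` reads >= 63 ug/mL, which is also only a limit. Going by the values given here, compound 3 `CNC(=O)c1cc(C(=O)N[C@H]2[C@@H]3COC[C@@H]32)cc2c1O[C@H](CF)[C@H]2c1ccccc1` gives 206 ug/mL, the one true number in the set. Compound 2 therefore stands on a limit alone, and no measured step connects any of these compounds.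

Compound 4 `CNC(=O)c1cc(C(=O)N[C@H]2CC[C@H](O)CC2)c([C@@H](C)c2ccc(Cl)cc2)o1` differs from compound 2 in one place: 4-chlorophenyl in place of 3-fluorophenyl on a saturated chain carbon bound to an aromatic carbon and a saturated chain carbon. In words, 4-chlorophenyl replaces 3-fluorophenyl on a saturated chain carbon bound to an aromatic carbon and a saturated chain carbon. Among the compounds with values here, with no measured step to lean on, the expectation rests on the limit of compound 2 and on the unchanged count of heavy atoms. The step of an at least 1.1-fold lower number from compound 2 to compound 4 (0.05 log units; that floor lies within the scatter) is expected to be small and slightly downward, within the usual scatter. For compound 4 the estimated value is 55 ug/mL, with an expected range of 20 ug/mL to 140 ug/mL.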

Compound 4, solubility: >= 118 ug/mL
Compound 4 gave a limit, no number; the forecaster's own chance of this, stated with the estimate: 35%; middle value at least 2.1-fold (0.33 log units) from the limit.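

No step can be read between compound 2 and compound 4 in this assay: each gives only a limit of the assay, not a number. Whether 4-chlorophenyl in place of 3-fluorophenyl shifts the reading at all, and in which direction, stays open among the compounds shown.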